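An aryl swap on the shared core: compound 3

The compounds below may be only part of what the source reports. "The series", "measured", "known", "first", "only" and "open" are said of these compounds alone.

Measured compounds:
compound 1, `COc1cc2ncnc(Nc3ccc(F)c(Cl)c3)c2cc1OCCCCC(=O)Nc1ccc(S(N)(=O)=O)cc1`, 15500 nM in a functional assay on A549 cells (Homo sapiens) for antiproliferative activity, read by MTT assay, with a stated time of 72 h; a lower number here means a stronger inhibitor, a higher number a weaker inhibitor
compound 2, `COc1cc2ncnc(Nc3ccc(F)c(Br)c3)c2cc1OCCCCC(=O)Nc1ccc(S(N)(=O)=O)cc1`, 16000 nM in this assay

Within the data shown here, compound 2 gives the highest of the two numbers in this assay, but its only neighbour is compound 1, and the step of a 1.0-fold higher number from compound 1 to compound 2 (0.01 log units; within the scatter) lies within the scatter, so the two compounds cannot be ordered. The unmeasured compound 3, `COc1ccccc1Nc1ncnc2cc(OC)c(OCCCCC(=O)Nc3ccc(S(N)(=O)=O)cc3)cc12`, keeps the shared core and the chain ending in the sulfonamide-bearing amide, and differs from compound 2 in one place: 2-methoxyphenyl in place of 3-bromo-4-fluorophenyl on a nitrogen on an aromatic ring. Among the measured compounds shown here, the single measured step, a 1.0-fold higher number from compound 1 to compound 2 (0.01 log units; within the scatter), exchanges one halogen for another on that ring and says nothing about replacing both halogens by a methoxy group at a different position of the ring. For the measured compounds named here, no measured step therefore bears on this change, and the expectation rests only on the narrow band occupied by compounds 1 and 2. Going by these compounds, compound 3 is expected to sit near that band, with a wide range to either side because the change is untested, so the estimate is 20000 nM (range 4000 nM to 100000 nM), which would be the step of a 1.3-fold higher number from compound 2 to compound 3 (0.10 log units; within the scatter).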

Compound 3, half-maximal inhibitory concentration: 24100 nM
The estimate for compound 3 lay 1.2-fold (0.08 log units) below the measured number; measured number inside the range.
By their numbers in this assay, from the lowest: compounds 1, 2 and 3 (each within the scatter of the next).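

In this assay, 2-methoxyphenyl in place of 3-bromo-4-fluorophenyl on the nitrogen gives a 1.5-fold higher number from compound 2 to compound 3 (0.18 log units; within the scatter), and the same group in place of 3-chloro-4-fluorophenyl gives a 1.6-fold higher number from compound 1 to compound 3 (0.19 log units; within the scatter). The earlier pair exchanged only one halogen for another, whereas these steps show that a ring with no halogen at all, carrying a methoxy group with its hydrogen-bond acceptor, stays within the scatter of both halogenated compounds, so the three cannot be ordered and this position shows no measurable response to this change. Nothing available offers an explanation for this result.

Because both halogens leave and the methoxy group enters in a single exchange, the compounds shown cannot separate the loss of the halogens from the arrival of the methoxy group, or tell whether the place of that group on the ring matters. Going by these compounds, it also remains open whether a plain phenyl, or a phenyl bearing an amine or a carboxylic acid, would move the number beyond the scatter, and whether a longer chain would do so.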